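A few compounds are considered here, and "the series" means these few. Any claim that something is new, unique, unknown or untested is made for them only; others in the source may bear on it.

Measured so far in a functional assay on U-266 cells (Homo sapiens) for antiproliferative activity, read by MTT assay, with a stated time of 72 h; a lower number here means a stronger inhibitor, a higher number a weaker inhibitor (read as half-maximal inhibitory concentration):

- compound 1 `COC(=O)C[C@H](NC(=O)/C(C#N)=C/c1cccc(Br)n1)c1ccccc1` gives 3300 nM
- compound 2 `N#C/C(=C\c1cccc(Br)n1)C(=O)N[C@H](c1ccccc1)C1CC1` gives "not determined" (no result reported)

Compound 2 therefore has no place on the numbers. For the measured compounds named here, it carries no single value in this assay, and the series has no measured step to read from. Going by the values given here, the only number in hand is that of compound 1, at 3300 nM in a single measurement, so any judgement here rests on thin ground.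

Next in line is compound 3 `CC(=O)OC[C@H](NC(=O)/C(C#N)=C/c1cccc(Br)n1)c1ccccc1`, still unmeasured in this assay. The change is acetoxymethyl in place of cyclopropyl on a saturated chain carbon bound to an amide-type nitrogen and an aromatic carbon, and the rest of the structure stays the same.

With no value for compound 2, the size and direction of this step cannot be read from the data. The working expectation is that compound 3 will land in the same range as compound 1 at 3300 nM, with no gap beyond the usual scatter, though the range is kept wide.

For compound 3 the expected value is 3000 nM, with an estimated range of 1000 nM to 9000 nM in this assay.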

Compound 3, half-maximal inhibitory concentration: 2800 nM
For compound 3 the middle estimate is 1.1-fold (0.03 log units) above the measured one, and the stated range covers the measured number.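

In this assay the series now has its first readable step, a 1.2-fold lower number from compound 1 to compound 3 (0.07 log units; within the scatter), and it lies within the scatter. On a saturated chain carbon, two bonds along the chain from an amide-type nitrogen and an aromatic carbon, acetoxy in place of methoxycarbonyl therefore gives two compounds that read alike, so this position tolerates that exchange of one ester arrangement for the other with the rest of the structure held constant. The step from compound 2 to compound 3, cyclopropyl to acetoxymethyl, cannot be read, and no measured evidence accompanies the result to account for the match between compound 1 and compound 3.

As far as these compounds go, both readable compounds carry an ester on this side chain, so it remains open whether a carboxylic acid, a primary amide or a free hydroxymethyl group at this place would read in the same range. A longer chain carrying the ester, or a simple amine in its place, is equally open, and the compounds shown say nothing about how far this position tolerates groups other than esters.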